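Replacing the Phenyl at the Carbonyl of Compound 1

This account rests on a few compounds, and the source may have more. Where it says the series, first, only, none or still open, it means among the compounds named here.

Compound 1 `O=C(NN=C1C(Cl)=C(Cl)C(Cl)=C1Cl)c1ccccc1` has been tested in a functional assay on RPMI-8226 cells (Homo sapiens) for cytotoxicity, read by MTT assay, with a stated time of 48 h (on this read-out lower numbers stand for stronger inhibition and higher numbers for weaker inhibition), where compound 1 gives 600 nM. Of the two numbers available, that of compound 1 is the highest, and its nearest neighbour is compound 2 `Fc1cccc(NN=C2C(Cl)=C(Cl)C(Cl)=C2Cl)c1`, which in this assay gives 500 nM; the gap between the two lies within the usual scatter, so they stand as equals. Compound 3 `Fc1ccccc1NN=C1C(Cl)=C(Cl)C(Cl)=C1Cl` gives in this assay only > 3000 nM, which is a limit of the assay and not a number (the limit of > 3000 nM in this assay, at which 1 of the 3 values shown sits).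

Compound 4 `C#CC(C)(C)OC(=O)NN=C1C(Cl)=C(Cl)C(Cl)=C1Cl` has not yet been measured. It differs from compound 1 in a single place: (1,1-dimethylprop-2-yn-1-yl)oxy in place of phenyl on a carbonyl carbon. Within the data shown here, since no pair of measured compounds differs by just one change, no measured step shows how far such a swap can move the read-out. The expectation is therefore drawn from the change itself, in which a six-membered aromatic ring of carbon only leaves and a chain carrying a triple bond and an oxygen enters at the carbonyl carbon. The step from compound 1 to compound 4 is estimated at a 2.5-fold higher number from compound 1 to compound 4 (0.40 log units; beyond the scatter), a modest weakening that could still fall inside the scatter. In this assay compound 4 is expected to give 1500 nM, within the range 500 nM to 5000 nM.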

Compound 4, half-maximal inhibitory concentration: > 5000 nM
Compound 4 ended at the assay's limit (the forecaster's own chance of this, stated with the estimate: 30%); at least 3.3-fold (0.52 log units) between middle value and limit.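

Among these compounds, this is the first single-place step in the set, and it shows that the group on the carbonyl carbon is not a free choice: in this assay, putting (1,1-dimethylprop-2-yn-1-yl)oxy in place of phenyl gives an at least 8.3-fold higher number from compound 1 to compound 4 (0.92 log units; beyond the scatter). The two groups hold 6 heavy atoms each, so in this one pair an equal heavy-atom count did not keep the read-out in place. The value for compound 4 is a limit of the assay and not a number: the limit of > 5000 nM in this assay, at which 1 of the 4 values shown sits.

The compounds shown leave open which part of the change matters most, since the aromatic ring leaves while an oxygen and a triple bond enter together, and this single step cannot pull those apart. A cyclohexyl ring on the same carbonyl carbon would test the loss of the aromatic ring alone, while a benzyloxy group would keep an aromatic ring and bring in the oxygen, and neither is among the compounds shown here.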